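A few compounds are considered here, and "the series" means these few. Any claim that something is new, unique, unknown or untested is made for them only; others in the source may bear on it.

Measured so far:
compound 1 `COc1ncccc1C(=O)NCCC1CCN(S(=O)(=O)NC(=O)NC2CCCCC2)CC1`: 33%
compound 2 `COc1ncccc1C(=O)NCCC1CCN(S(=O)(=O)NC(=O)NC[C@H]2C[C@@H]3CC[C@@H]2O3)CC1`: 14%

Among the compounds with values here, in a functional assay on the whole organism (blood) with Rattus norvegicus as the target, with stated times of 24 h and 1 h, at a dose of 5 mg/kg by the intraperitoneal route (a lower number here means a weaker effect, a higher number a stronger effect of the compound at the dose given), compound 2 gives 14%, the lower of the two numbers; the only neighbour, compound 1, sits higher by the step of a number 19 percentage points lower from compound 1 to compound 2 (beyond the scatter), which lies beyond the scatter.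

Compound 3 `COc1ncccc1C(=O)NCCC1CCN(S(=O)(=O)NC(=O)NCC2CCCCO2)CC1` has not been measured. It differs from compound 2 in one place: a group of 6 heavy atoms (5 carbon, 1 oxygen; one six-membered non-aromatic ring with 1 hetero atom) in place of a group of 7 heavy atoms (6 carbon, 1 oxygen; 2 five-membered non-aromatic rings with 1 hetero atom each), on a saturated chain carbon bound to an amide-type nitrogen.

Within the data shown here, no measured step matches this change. Among the measured compounds shown here, the only step at hand, a number 19 percentage points lower from compound 1 to compound 2 (beyond the scatter), concerns the same part of the molecule: the bicyclic group gave a weaker effect than the six-membered ring of carbon only. The oxan-2-yl group of compound 3 is again one six-membered non-aromatic ring, so a partial return toward the level of compound 1 is expected, though the saturated chain carbon between ring and nitrogen remains as in compound 2. The expected step is a number 8 percentage points higher from compound 2 to compound 3 (within the scatter), of modest size and upward. Compound 3 is therefore estimated at 22%, within 8% to 38%.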

Compound 3, a percentage reported as activity, at one dose (the size of the read-out at that dose, not a potency): 12%
Compound 3: the middle estimate sits 10 percentage points above what was measured; low and high end bracket the measured number.
By their numbers in this assay, from the lowest: compounds 3 and 2 (each within the scatter of the next); then compound 1.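

In this assay, oxan-2-yl in place of the bicyclic group on a saturated chain carbon bound to an amide-type nitrogen gives a number 2 percentage points lower from compound 2 to compound 3 (within the scatter) and so does not separate compound 3 from compound 2, although the ring is again a single six-membered non-aromatic ring. (Oxan-2-yl)methyl in place of cyclohexyl on an amide-type nitrogen gives a number 21 percentage points lower from compound 1 to compound 3 (beyond the scatter) and leaves compound 1, the only one with cyclohexyl placed directly on that nitrogen, apart from the other two. No measurement at hand offers an explanation for these numbers.

The change from compound 1 to compound 3 brings in both the ring oxygen and the saturated chain carbon, and the compounds shown leave open which of the two accounts for the step. As far as these compounds go, a cyclohexylmethyl group on the amide-type nitrogen would separate the two, and the effect of an amine on the ring also remains open.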